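The source may report more compounds than this note shows. Statements on the series, on what has been measured and on what is new or still open speak of the compounds shown alone.

Measured compounds:
compound 1 `Cc1nc(N)sc1CCCN/C(N)=N/C(=O)N[C@@H](C)c1ccccc1`: 51.3 nM
compound 2 `Cc1nc(N)sc1CCCN/C(N)=N/C(=O)NCC(C)CC1CCCCC1`: 70.8 nM
compound 3 `Cc1ccc(CC(C)CNC(=O)/N=C(\N)NCCCc2sc(N)nc2C)cc1`: 72.4 nM

In an assay on membranes from Sf9 cells for displacement of a labelled ligand from histamine H2 receptor (Homo sapiens), read by scintillation counting, with a stated time of 60 min (on this read-out higher numbers stand for weaker inhibition and lower numbers for stronger inhibition), compound 1 gives the lowest of the three numbers, though its gaps to compound 2 and compound 3 both lie within the scatter, so no order among them can be claimed. Going by the values given here, the only single-point step among the measured compounds is a 1.0-fold higher number from compound 2 to compound 3 (0.01 log units; within the scatter), where an aromatic ring replaced a saturated ring without moving the number. Compound 4 `Cc1nc(N)sc1CCCN/C(N)=N/C(=O)NC(C)c1cccs1` differs from compound 1 by 1-(thiophen-2-yl)ethyl in place of 1-phenylethyl on an amide-type nitrogen. Among the compounds with values here, no measured step covers this exact exchange, and the one measured ring swap was flat, so no shift beyond the scatter is expected in this assay. Compound 4 is therefore estimated at 55 nM, within 25 nM to 120 nM, a step of a 1.1-fold higher number from compound 1 to compound 4 (0.03 log units; within the scatter).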

Compound 4, inhibition constant: 63.1 nM
For compound 4 the middle estimate is 1.1-fold (0.06 log units) below the measured one, within the range that was stated.
By their numbers in this assay, from the lowest: compounds 1, 4, 2 and 3 (each within the scatter of the next).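

In this assay the exchange of 1-phenylethyl for 1-(thiophen-2-yl)ethyl on an amide-type nitrogen gives a 1.2-fold higher number from compound 1 to compound 4 (0.09 log units; within the scatter), so at this position a five-membered aromatic ring with a sulfur atom leaves the number in place, as a six-membered carbon ring does. The entering group has no defined stereocentre while the leaving group has one, and the step spans that difference as well. Nothing available explains this flat result. On these data alone, whether a pyridine ring, or a carboxylic acid on the aromatic ring, would also leave the number in place stays open, as does how the two mirror forms of compound 4 compare.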